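Methylating the hydroxy of compound 3: expected paw edema inhibition

This account rests on a few compounds, and the source may have more. Where it says the series, first, only, none or still open, it means among the compounds named here.

Compound 3 `CCOC(=O)C(=O)Nc1ccccc(O)c1=O` gives the highest of the three numbers in a functional assay on the whole organism (strain Sprague-Dawley CD) for inhibition, with Rattus norvegicus as the target, read by paw edema, at a dose of 30 mg/kg by the intraperitoneal route (a lower number here means a weaker effect, a higher number a stronger effect of the compound at the dose given), at 61%. Compound 2 `CCOC(=O)C(=O)Nc1ccccc(C)c1=O` stands close to it with 60%, a gap that is within the scatter (a number 1 percentage points higher from compound 2 to compound 3 (within the scatter)). Compound 1 `CCOC(=O)C(=O)Nc1ccccc(Oc2ccccc2)c1=O` is far weaker, giving 16% in this assay. Compound 4 `CCOC(=O)C(=O)Nc1ccccc(OC)c1=O` differs from compound 3 by methyl in place of hydrogen on an oxygen on an aromatic ring. The step that bears most directly on this is a number 45 percentage points higher from compound 1 to compound 3 (beyond the scatter), showing how much a phenyl on this oxygen costs, while a number 1 percentage points higher from compound 2 to compound 3 (within the scatter) shows hydroxy and methyl on the carbon giving the same result. A methyl on the oxygen is less than a phenyl, so only a modest loss in this assay is expected: a number 11 percentage points lower from compound 3 to compound 4 (beyond the scatter). Compound 4 is therefore estimated at 50%, in the range 30% to 68%.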

Compound 4, a percentage reported as inhibition, in the whole organism at one dose (the size of the read-out at that dose, not a potency): 52%
The estimate for compound 4 lay 2 percentage points below the measured number; the measured number falls inside the stated range.
By their numbers in this assay, from the lowest: compound 1; then compounds 4, 2 and 3 (each within the scatter of the next).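

Putting a methyl on the oxygen leaves the read-out in this assay essentially unchanged (a number 9 percentage points lower from compound 3 to compound 4 (within the scatter)), and methoxy also matches methyl on the aromatic carbon (a number 8 percentage points lower from compound 2 to compound 4 (within the scatter)). The earlier loss therefore does not follow from any group on this oxygen: it goes with phenyl, as methyl restores the effect (a number 36 percentage points higher from compound 1 to compound 4 (beyond the scatter)). Nothing available explains this difference.

As far as these compounds go, whether an ethoxy, a longer chain or a benzyl on this oxygen stays with compound 4 or falls towards compound 1 remains open. So does the effect of an amine or a carboxylic acid on this aromatic carbon.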